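Chloro in Place of Phenoxy: A Clearance Estimate

A few compounds are considered here, and "the series" means these few. Any claim that something is new, unique, unknown or untested is made for them only; others in the source may bear on it.

In an in vitro ADME assay on microsomes from liver (Mus musculus, strain CD1) for metabolic stability, read by HPLC, with a stated time of 4 h (on this read-out lower numbers stand for slow clearance and higher numbers for fast clearance), compound 1 `CCOC(=O)c1c(-c2cccc(OCC)c2)[nH]c2cc(OC)ccc2c1=O` gives 12 mL.min-1.g-1 and compound 2 `CCOC(=O)c1c(-c2cccc(Oc3ccccc3)c2)[nH]c2cc(OC)ccc2c1=O` gives 35 mL.min-1.g-1. Within the data shown here, compound 2 therefore holds the higher of the only two numbers so far. Among the measured compounds shown here, the single measured step, a 2.9-fold higher number from compound 1 to compound 2 (0.46 log units; beyond the scatter), put phenyl in place of ethyl on an oxygen on an aromatic ring. It was modest but beyond the scatter.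

The next compound is compound 3 `CCOC(=O)c1c(-c2cccc(Cl)c2)[nH]c2cc(OC)ccc2c1=O`, which has chloro in place of phenoxy on an aromatic carbon. For the measured compounds named here, no measured step involves chloro, so the evidence is thin and only indirect. Like compound 1, compound 3 lacks the phenyl of compound 2, and the step of a 2.9-fold higher number from compound 1 to compound 2 (0.46 log units; beyond the scatter) is the only guide to what losing it may mean. A step of similar modest size is therefore expected, towards a lower number and not far from compound 1 (12 mL.min-1.g-1).

The expected step in this assay is a 2.2-fold lower number from compound 2 to compound 3 (0.34 log units; beyond the scatter). For compound 3 the estimate is 16 mL.min-1.g-1 (expected range 7 mL.min-1.g-1 to 35 mL.min-1.g-1).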

Compound 3, intrinsic clearance in microsomes: 16 mL.min-1.g-1
Compound 3: middle estimate and measured number agree at the digits printed, within the range that was stated.
By their numbers in this assay, from the lowest: compounds 1 and 3 (each within the scatter of the next); then compound 2.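

At this position, on an aromatic carbon of a six-membered aromatic ring of carbon only, this assay now shows that the phenoxy group can be exchanged for a single chlorine atom with a modest drop in the number (a 2.2-fold lower number from compound 2 to compound 3 (0.34 log units; beyond the scatter)), so compound 2 stands apart from both other compounds by a step beyond the scatter. The exchange of ethoxy for chloro gives a step within the scatter (a 1.3-fold higher number from compound 1 to compound 3 (0.12 log units; within the scatter)), so this read-out does not separate the two smaller groups, although chloro carries neither the oxygen nor the carbon chain of ethoxy. No measurement shown here accounts for these numbers.

The compounds shown leave open whether an amine, a carboxylic acid or a longer alkoxy chain at this position would give a number close to those of compound 1 and compound 3 or one closer to that of compound 2. They also leave open whether the same exchanges would give steps of similar size at another place on the ring or on a different core, as all three compounds share one core and one substituted position.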